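The source may report more compounds than this note shows. Statements on the series, on what has been measured and on what is new or still open speak of the compounds shown alone.

Measured so far:
Compound 1, `CCCc1nc(-c2ccccc2)c(CNCCN2CCN(c3ccc(Cl)cc3)CC2)o1`: 2820 nM in an assay on HEK293 cells for inhibition of Voltage-dependent T-type calcium channel subunit alpha-1G (Homo sapiens), read by patch clamp; on this read-out lower numbers stand for stronger inhibition and higher numbers for weaker inhibition
Compound 2, `CCCc1nc(-c2ccccc2)c(CNCCCN2CCN(c3ccc(F)cc3)CC2)o1`: 3210 nM in this assay
Compound 3, `CCCc1nc(-c2ccccc2)c(CNCCCN2CCN(c3cccc(Cl)c3)CC2)o1`: 1750 nM in this assay

Among these three numbers compound 1 stands second highest. Its nearest neighbour is compound 2, and the gap between them lies within the scatter; its furthest neighbour is compound 3, and that gap, too, lies within the scatter. For the measured compounds named here, no compound can therefore be called stronger or weaker than another on what has been measured.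

Compound 4, `CCCc1nc(-c2ccccc2)c(CNCCN2CCN(c3ccc(C(F)(F)F)cc3)CC2)o1`, has not yet been measured in this assay. It arises from compound 1 by one change: trifluoromethyl in place of chloro on an aromatic carbon. Going by the values given here, the only step measured between two compounds that differ in one place is a 1.8-fold lower number from compound 2 to compound 3 (0.26 log units; within the scatter), which exchanges one ring substituent for another, much as the step from compound 1 to compound 4 does, but neither its groups nor its place match the present change, and it stayed within the scatter. Among the compounds with values here, there is thus no measured step that bears directly on the move from chloro to trifluoromethyl, and nothing that argues for a shift beyond the scatter.

The expectation for compound 4 in this assay is accordingly a step of about a 1.0-fold lower number from compound 1 to compound 4 (0.00 log units; within the scatter), which means a value near 2800 nM, with a plausible range from 1000 nM to 8000 nM.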

Compound 4, half-maximal inhibitory concentration: 1300 nM
Beside the measured number, compound 4's estimate is 2.2-fold (0.33 log units) above it; the range from low to high includes it.
By their numbers in this assay, from the lowest: compounds 4, 3, 1 and 2 (each within the scatter of the next, the first and the last beyond it).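

In this assay, trifluoromethyl in place of chloro on an aromatic carbon, para to a large group, gives a 2.2-fold lower number from compound 1 to compound 4 (0.34 log units; beyond the scatter), a modest step and the first one among these compounds to pass beyond the scatter. The only earlier step, a 1.8-fold lower number from compound 2 to compound 3 (0.26 log units; within the scatter), stayed within the scatter and altered both the group and its place on the ring, whereas here the place, the chain and the rest of the core of compound 1 stay the same, so the number is shown to respond to the group at this one place. No measurement at hand gives a reason for this step.

As far as these compounds go, the finding rests on a single pair of compounds, so it remains open whether the same exchange would give a like step on the chain carried by compound 2 and compound 3. From the compounds shown here alone, it also remains open how other groups at this place, such as bromo, methyl, methoxy or nitrile, would stand against chloro and trifluoromethyl, and whether trifluoromethyl would give a like step at another place on the ring.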